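Nitro substitution on the pyrazole-bound phenyl: compound 3 to 4

The compounds below may be only part of what the source reports. "The series", "measured", "known", "first", "only" and "open" are said of these compounds alone.

Measured so far in a functional assay on the whole organism (strain Wistar albino) for inhibition, with Rattus norvegicus as the target, read by paw edema, with a stated time of 3 h, at a dose of 25 mg/kg by the oral route; a higher number here means more inhibition at the dose given (going by the name of the read-out), a lower number less inhibition:
compound 1 `CSc1nn(-c2ccccc2)c2nc(Nc3ccccc3)n(-c3ccccc3)c(=O)c12` — 25.4%
compound 2 `CSc1nn(-c2ccc([N+](=O)[O-])cc2)c2nc(Nc3ccccc3)n(-c3ccccc3)c(=O)c12` — 26.6%
compound 3 `O=c1c2c(Nc3ccccc3)nn(-c3ccccc3)c2nc(Nc2ccccc2)n1-c1ccccc1` — 17.1%

Compound 3 gives the lowest of the three numbers in this assay, but the step between it and compound 1 is a number 8.3 percentage points lower from compound 1 to compound 3 (within the scatter), and the gap to compound 2 is also within the scatter, so the three compounds cannot be ordered with confidence.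

Compound 4 `O=c1c2c(Nc3ccccc3)nn(-c3ccc([N+](=O)[O-])cc3)c2nc(Nc2ccccc2)n1-c1ccccc1` has not yet been measured. Its difference from compound 3 is nitro in place of hydrogen on an aromatic carbon. Among the measured compounds shown here, one measured step bears directly on this change: the same replacement, on the same ring, from compound 1 to compound 2, gave a number 1.2 percentage points higher from compound 1 to compound 2 (within the scatter). That step carries no movement beyond the scatter, so no movement beyond the scatter is expected here either; the only question is whether the replacement behaves the same on a core bearing the anilino group that compound 3 carries, and on that point the data are silent.

Compound 4 is therefore expected to give 18.5% in this assay, in the range 8% to 29%. This estimate means a step of a number 1.4 percentage points higher from compound 3 to compound 4 (within the scatter), essentially flat against compound 3.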

Compound 4, a percentage reported as inhibition, in the whole organism at one dose (the size of the read-out at that dose, not a potency): 14.1%
The estimate for compound 4 lay 4.4 percentage points above the measured number, and the stated range covers the measured number.
By their numbers in this assay, from the lowest: compounds 4, 3, 1 and 2 (each within the scatter of the next, the first and the last beyond it).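

In this assay, the change from phenyl to 4-nitrophenyl can now be read on a second core, a number 3 percentage points lower from compound 3 to compound 4 (within the scatter), and neither core shows a step beyond the scatter, with the two readings in agreement: the same change on two cores in this assay, a number 1.2 percentage points higher (within the scatter) from compound 1 to compound 2 and a number 3 percentage points lower (within the scatter) from compound 3 to compound 4, 4.2 percentage points apart, within the scatter of two such steps.
Placing anilino in place of methylsulfanyl on the nitro-bearing core gives a number 12.5 percentage points lower from compound 2 to compound 4 (beyond the scatter), the only step here beyond the scatter, and a modest one, yet this does not show that the nitro group enlarges that change: the same change on two cores in this assay, a number 8.3 percentage points lower (within the scatter) from compound 1 to compound 3 and a number 12.5 percentage points lower (beyond the scatter) from compound 2 to compound 4, 4.2 percentage points apart, within the scatter of two such steps.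
The four compounds thus close a square of two changes, and in this assay the effect of neither change is seen to depend on the other.

The nitro group is the only replacement for hydrogen shown at this place, so an amine or a carboxylic acid on the same aromatic carbon would test whether this position responds to any group at all. Anilino is likewise the only replacement for methylsulfanyl shown, which leaves open how a small group such as methylamino or a longer alkyl chain would read on either core.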